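Aryl variation on the shared core: towards compound 4

A few compounds are considered here, and "the series" means these few. Any claim that something is new, unique, unknown or untested is made for them only; others in the source may bear on it.

Three members of the series share one core and differ only in the aryl group attached to it. Compound 1 `Cc1nc2c3ccccc3ccc2c2nc3c(ccc4ccccc43)c(-c3cccc([N+](=O)[O-])c3)c12` carries a 3-nitrophenyl group and in a functional assay, read by spectrophotometry, with a stated time of 30 min (on this read-out lower numbers stand for stronger inhibition and higher numbers for weaker inhibition), compound 1 gives 117 ug/mL. Compound 2 `Cc1nc2c3ccccc3ccc2c2nc3c(ccc4ccccc43)c(-c3nccnc3N)c12` carries a 3-aminopyrazin-2-yl group, and in this assay compound 2 gives 81.7 ug/mL. Compound 3 `COc1ccc(-c2c3ccc4ccccc4c3nc3c2c(C)nc2c4ccccc4ccc32)cc1` carries a 4-methoxyphenyl group, and in this assay compound 3 gives 133 ug/mL. Compound 2 holds the lowest of the three numbers, but every step between them lies within the scatter: a 1.4-fold lower number from compound 1 to compound 2 (0.16 log units; within the scatter), a 1.1-fold higher number from compound 1 to compound 3 (0.06 log units; within the scatter) and a 1.6-fold higher number from compound 2 to compound 3 (0.21 log units; within the scatter).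

Compound 4 `Cc1nc2c3ccccc3ccc2c2nc3c(ccc4ccccc43)c(-c3cc(O)nc4ccccc34)c12` is not yet measured. Relative to compound 2 the change is 2-hydroxyquinolin-4-yl in place of 3-aminopyrazin-2-yl on an aromatic carbon. Among the measured compounds shown here, the steps that bear on it are those in which the aryl group alone was exchanged, above all the step of a 1.6-fold higher number from compound 2 to compound 3 (0.21 log units; within the scatter), which also started from the 3-aminopyrazin-2-yl group, and the step of a 1.4-fold lower number from compound 1 to compound 2 (0.16 log units; within the scatter). Both were within the scatter, so no step beyond the scatter is expected in this assay for the new aryl group either; the expected step is a 1.2-fold higher number from compound 2 to compound 4 (0.09 log units; within the scatter). Compound 4 is therefore estimated at 100 ug/mL, with a range from 50 ug/mL to 200 ug/mL.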

Compound 4, half-maximal inhibitory concentration: 92.1 ug/mL
Beside the measured number, compound 4's estimate is 1.1-fold (0.04 log units) above it; low and high end bracket the measured number.
By their numbers in this assay, from the lowest: compounds 2, 4, 1 and 3 (each within the scatter of the next).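

In this assay, the aromatic carbon opposite the ring nitrogen also accepts 2-hydroxyquinolin-4-yl, with 11 heavy atoms and two six-membered aromatic rings, in place of 3-aminopyrazin-2-yl, with 7 heavy atoms and one such ring, and the result is a 1.1-fold higher number from compound 2 to compound 4 (0.05 log units; within the scatter). The exchanges from the other two aryl groups are also within the scatter, a 1.4-fold lower number from compound 3 to compound 4 (0.16 log units; within the scatter) and a 1.3-fold lower number from compound 1 to compound 4 (0.10 log units; within the scatter), so the read-out does not separate any of the four aryl groups now on record, including this first one with a second ring. No other data accompany these numbers, so the result can be described but not explained.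

As far as these compounds go, all four groups are aromatic and joined through a ring carbon, so it remains open whether a non-aromatic group at this position, such as a simple amine, a carboxylic acid or a longer alkyl chain, would give a step beyond the scatter. Also open, from the compounds shown here alone, is how changes elsewhere would read, as the rest of the shared core is the same in all four compounds.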